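Butyl to 2-methylprop-1-en-1-yl: working notes

This account rests on a few compounds, and the source may have more. Where it says the series, first, only, none or still open, it means among the compounds named here.

In a physicochemical assay for lipophilicity (on this read-out lower numbers stand for lower lipophilicity and higher numbers for higher lipophilicity), compound 2 `CCCCCN(C1=NCCN1)c1c(Br)cccc1Br` gives 0.32, the highest of the three numbers. Compound 3 `C=C(C)CN(C1=NCCN1)c1c(Br)cccc1Br` gives -0.66, and compound 1 `CCN(C1=NCCN1)c1c(Br)cccc1Br` gives -1.01.

Compound 4 `CC(C)=CCN(C1=NCCN1)c1c(Br)cccc1Br` is still unmeasured. It differs from compound 2 by 2-methylprop-1-en-1-yl in place of butyl on a saturated chain carbon bound to a nitrogen on an aromatic ring.

The closest measured change replaces butyl with 1-methylethenyl at the same place, giving a number 0.98 log units lower from compound 2 to compound 3 (beyond the scatter). Two further steps frame it. Propyl in place of hydrogen on the chain gave a number 1.33 log units higher from compound 1 to compound 2 (beyond the scatter), and 1-methylethenyl in place of methyl gave a number 0.35 log units higher from compound 1 to compound 3 (beyond the scatter).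

Unlike 1-methylethenyl, the group entering compound 4 matches butyl in carbon count, so only part of the drop seen with compound 3 is expected to carry over. A fall in this assay is therefore expected, beyond the scatter but smaller than the closest step. The expected change is a number 0.52 log units lower from compound 2 to compound 4 (beyond the scatter). The estimated value for compound 4 is -0.2, within an expected range from -0.6 to 0.2.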

Compound 4, distribution coefficient: -0.14
For compound 4 the middle estimate is 0.06 log units below the measured one, and the stated range covers the measured number.
By their numbers in this assay, from the lowest: compound 1; then compound 3; then compound 4; then compound 2.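

In this assay, the step from butyl to 2-methylprop-1-en-1-yl leaves the count of four carbons unchanged and adds one double bond outside aromatic rings, yet it still gives a number 0.46 log units lower from compound 2 to compound 4 (beyond the scatter), so carbon count alone does not set the number at this place, on a saturated chain carbon bound to a nitrogen on an aromatic ring. The two groups carrying a double bond also do not read alike: 2-methylprop-1-en-1-yl in place of 1-methylethenyl gives a number 0.52 log units higher from compound 3 to compound 4 (beyond the scatter), and in place of methyl it gives a number 0.87 log units higher from compound 1 to compound 4 (beyond the scatter), so the group entering compound 4 stands apart from both smaller groups as well as from butyl. No supporting data bear on why these steps take the sizes they do.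

Still open, going by these compounds, is how much of the step from butyl goes with the double bond and how much with the branching, a split that 2-methylpropyl at this place would help to separate. Also open, on these data alone, is whether a longer chain carrying a double bond, or a chain ending in an amine, would follow the same order.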